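The source may report more compounds than this note shows. Statements on the series, on what has been measured and on what is new or still open speak of the compounds shown alone.

Measured in a functional assay on HT-1080 cells (Homo sapiens) for antiproliferative activity, read by MTT assay, with a stated time of 72 h; a lower number here means a stronger inhibitor, a higher number a weaker inhibitor:
Compound 1 `COc1ccc(-c2ss/c(=N/O)c2-c2cc(OC)c(OC)c(OC)c2)cc1`: 6660 nM
Compound 2 `COc1ccc(-c2c(-c3cc(OC)c(OC)c(OC)c3)ss/c2=N/O)cc1`: > 100000 nM, a limit of the assay and not a number
Compound 3 `COc1ccc(-c2c(-c3cc(OC)c(OC)c(OC)c3)ss/c2=N/O)cc1N`: 2910 nM

Only two of these results are true numbers. Of those two, compound 3 has the lower, at 2910 nM, while compound 1 is nearest at 6660 nM, a gap beyond the usual scatter.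

The next compound, compound 4 `CO/N=c1/ssc(-c2cc(OC)c(OC)c(OC)c2)c1-c1ccc(OC)c(N)c1`, has not yet been measured. It differs from compound 3 by methyl in place of hydrogen on an oxygen, with that oxygen's other neighbour a double-bonded nitrogen, so hydroxy becomes methoxy.

Among the compounds with values here, only one measured step is available, and it bears on this change only indirectly. That step, an at least 34-fold lower number from compound 2 to compound 3 (1.53 log units; beyond the scatter), is a different change, amino in place of hydrogen on an aromatic carbon, and it starts from the limit of > 100000 nM in this assay, at which 1 of the 3 values shown sits. Within the data shown here, no measured step tests methyl on this oxygen, so the data favour neither direction. The central expectation is therefore no clear shift, stated as an expected 1.0-fold higher number from compound 3 to compound 4 (0.01 log units; within the scatter). The expected range stays wide because an at least 34-fold lower number from compound 2 to compound 3 (1.53 log units; beyond the scatter) shows how far one small change can move the number in this set. Compound 4 is estimated at 3000 nM, with an expected range from 600 nM to 20000 nM.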

Compound 4, half-maximal inhibitory concentration: 915 nM
Compound 4: the middle estimate sits 3.3-fold (0.52 log units) above what was measured; the range from low to high includes it.
By their numbers in this assay, from the lowest: compound 4; then compound 3; then compound 1. At a limit, above all of these: compound 2.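

In this assay, within the data shown here, this is the first measured change on the oxygen whose other neighbour is a double-bonded nitrogen, and hydroxy to methoxy gives a 3.2-fold lower number from compound 3 to compound 4 (0.50 log units; beyond the scatter). The hydrogen on this oxygen is therefore not needed for activity in this pair: capping it with a methyl group lowers the number by a modest step rather than losing the activity, whereas the earlier step showed only what an amino group on the aromatic ring can do. Among these compounds, nothing measured here says why the methyl group has this effect, and the one available piece of evidence, about a limit of the assay reached by compound 2, does not bear on this change.

The compounds shown leave open whether an ethyl group or a longer chain on this oxygen would lower the number further or raise it again, and how a carboxylic acid at the end of such a chain would fare. They also leave open whether methoxy in place of hydroxy would move the number in the same direction in compound 1 or compound 2, neither of which carries the amino group.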